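Piperidin-1-yl in place of ethoxy on compound 2

The source may hold more compounds than are shown below. What is called first, only, known or untested is meant among the compounds shown, and "the series" means these compounds.

Of the compounds shown here, three sharing one core have been measured in a functional assay on cells (Neutrophil, Homo sapiens) for inhibition, with a stated time of 10 min (a lower number here means a stronger inhibitor, a higher number a weaker inhibitor), as inhibitors. Compound 1 `CCOC(=O)c1cnn2c1N(C(=O)Nc1ccccc1)C(c1ccccc1)C2` gives > 1000 nM here, which is a limit and not a number. Compound 3 `CCOC(=O)c1cnn2c1N(C(=O)Nc1ccc(F)cc1)C(c1ccccc1)C2` gives > 1000 nM here, again a limit and not a number. Compound 2 `CCOC(=O)c1cnn2c1N(C(=O)Nc1cccc(F)c1)C(c1ccccc1)C2` gives 111 nM and is the only one of the three with an actual number. Fluoro in place of hydrogen on an aromatic carbon makes an at least 9.0-fold lower number from compound 1 to compound 2 (0.95 log units; beyond the scatter) as its effect, while 4-fluorophenyl in place of 3-fluorophenyl on an amide-type nitrogen makes an at least 9.0-fold higher number from compound 2 to compound 3 (0.95 log units; beyond the scatter) as its effect. Compound 4 `O=C(c1cnn2c1N(C(=O)Nc1cccc(F)c1)C(c1ccccc1)C2)N1CCCCC1` keeps the 3-fluorophenyl of compound 2 and differs elsewhere (piperidin-1-yl in place of ethoxy on a carbonyl carbon), with piperidin-1-yl in place of ethoxy on a carbonyl carbon. Neither measured step touches that place, so they bear on it only indirectly: they show how sharply the numbers can move on a small change, and the limit of > 1000 nM in this assay, at which 2 of the 3 values shown sit, marks how easily a compound of this set reaches the limit. A modest weakening is therefore expected, though with little certainty. In this assay the expected change is a 3.2-fold higher number from compound 2 to compound 4 (0.50 log units; beyond the scatter) in estimate. For compound 4 the estimated value is 350 nM (expected range 70 nM to 1800 nM) for now.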

Compound 4, half-maximal inhibitory concentration: 1.2 nM
Estimate against measurement, compound 4: 290-fold (2.46 log units) above; measured number below the stated range.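

Before this result, the only changes seen concerned the fluoro on the aromatic ring carried by the amide-type nitrogen, and the carbonyl position had stayed fixed as the ethoxycarbonyl. In this assay, piperidin-1-yl in place of ethoxy on a carbonyl carbon gives a 93-fold lower number from compound 2 to compound 4 (1.97 log units; beyond the scatter), so this position is far from a passive one, and the ethoxy is not needed there, since a group with a six-membered non-aromatic ring is accepted in its place with a large gain. Unlike the fluoro steps, which are bounded on one side by a limit, this step is read between two actual numbers, well clear of the ceiling of the set: the limit of > 1000 nM in this assay, at which 2 of the 4 values shown sit.

The compounds shown leave open what carries the step, as ethoxy and piperidin-1-yl differ in several ways at once, and a diethylamino group, a morpholin-4-yl or a pyrrolidin-1-yl on the same carbonyl would begin to separate the ring, its size and the amide nitrogen. They also leave open whether the 3-fluorophenyl remains decisive once the piperidin-1-yl is present, which a 4-fluorophenyl or an unsubstituted phenyl alongside that group would test.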